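The source may report more compounds than this note shows. Statements on the series, on what has been measured and on what is new or still open speak of the compounds shown alone.

Compound 1, `O=C1CSC(c2ccc(F)cc2)N1CCN1CCCCC1`: 100%
Compound 2, `COc1ccc(C2SCC(=O)N2CCN2CCCCC2)cc1`: 100%
Compound 3, `O=C1CSC(c2ccc([N+](=O)[O-])cc2)N1CCN1CCCCC1`: 100%

All three compounds were tested in an ADME assay on Vero cells (Chlorocebus sabaeus) for cytotoxicity, read by neutral red uptake, tested at 25 ug/mL; a higher number here means a weaker effect of the compound at the concentration tested, a lower number a stronger effect. Compound 1 sits level with compounds 2 and 3, and none of the three shows any effect at the concentration used. The three share one core and differ only in the group on the aromatic ring: the step of no change at the digits printed from compound 1 to compound 2 (within the scatter) swaps methoxy in for fluoro, and the step of no change at the digits printed from compound 1 to compound 3 (within the scatter) swaps nitro in for fluoro, and neither moves the read-out.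

Compound 4, `O=C1CSC(c2cccc(O)c2)N1CCN1CCCCC1`, has not yet been tested. It differs from compound 1 in one place: 3-hydroxyphenyl in place of 4-fluorophenyl on a saturated ring carbon. This is again a change of the group on the aromatic ring that hangs from the core, so the two steps from compound 1 to compound 2 and from compound 1 to compound 3 are the ones that bear on it. Both were flat. The new group is a 3-hydroxyphenyl, which brings one hydrogen-bond donor and one acceptor that the fluorophenyl lacks, but nothing in the data ties such a difference to a change in this read-out.

Compound 4 is therefore expected to show no step beyond the scatter, no change at the digits printed from compound 1 to compound 4 (within the scatter). The estimated value for compound 4 is 100%, with a range from 88% to 100%.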

Compound 4, a percentage reported as activity, at one concentration (the size of the read-out at that concentration, not a potency): 100%
The estimate for compound 4 equals the measured number at the digits printed; the range from low to high includes it.
By their numbers in this assay, from the lowest: compounds 1, 2, 3 and 4 (each within the scatter of the next).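

In this assay, replacing 4-fluorophenyl with 3-hydroxyphenyl on the saturated ring carbon gives no change at the digits printed from compound 1 to compound 4 (within the scatter). The earlier steps shown here only exchanged one group for another on the aromatic ring, whereas this one also brings in a hydrogen-bond donor, which 4-fluorophenyl lacks, and changes the number in the group's name from 4 to 3, so the flat result now covers a broader kind of change at this position. Among these compounds, the single step cannot separate the effect of the hydroxyl group from that of its new place on the ring, and no measurement here offers an explanation for the unchanged read-out.

All the compounds shown keep a substituted phenyl group on this carbon, so it remains open whether an amine or a carboxylic acid on that ring, or a longer chain in place of the ring, would lower the number. With all four compounds level, they also do not show which part of the shared core, if any, could produce an effect in this assay.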